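The source may hold more compounds than are shown below. What is called first, only, known or untested is meant among the compounds shown, and "the series" means these compounds.

Working notes on the series in an ADME assay on Caco-2 cells (Homo sapiens) for permeability, in the apical to basolateral direction; on this read-out lower numbers stand for lower permeability and higher numbers for higher permeability. Compound 1 `Cn1cncc1CN1CC(N(Cc2ccc(S(C)(=O)=O)cc2)S(=O)(=O)c2ccccn2)Cc2cc(C#N)ccc21` gives 0.2 10^-6 cm/s in this assay. Compound 3 `Cn1cnc(S(=O)(=O)N(CCn2cccc2)C2Cc3cc(C#N)ccc3N(Cc3cncn3C)C2)c1` gives 0.3 10^-6 cm/s. Compound 2 `Cn1cncc1CN1CC(N(CC2CCN(C(=O)N3CCCCC3)CC2)S(=O)(=O)c2ccccn2)Cc2cc(C#N)ccc21` gives 0.6 10^-6 cm/s; it stands at the top of the three numbers, with the gap to compound 1 beyond the usual scatter, whereas compound 3 lies within the scatter of compound 2, so no order between those two is read. Compound 4 `Cn1cncc1CN1CC(N(CC2CCN(C(=O)C3CCCC3)CC2)S(=O)(=O)c2ccccn2)Cc2cc(C#N)ccc21` is not yet measured and differs from compound 2 in one place: cyclopentyl in place of piperidin-1-yl on a carbonyl carbon. Within the data shown here, with no comparable pair among the measured compounds, a step of no more than the scatter is expected here, if anything upward. Compound 4 is therefore estimated at 0.8 10^-6 cm/s, within 0.3 10^-6 cm/s to 2 10^-6 cm/s, which means an expected step of a 1.3-fold higher number from compound 2 to compound 4 (0.12 log units; within the scatter).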

Compound 4, apparent permeability: 0.5 10^-6 cm/s
Estimate against measurement, compound 4: 1.6-fold (0.20 log units) above; low and high end bracket the measured number.
By their numbers in this assay, from the lowest: compounds 1, 3, 4 and 2 (each within the scatter of the next, the first and the last beyond it).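

In this assay, the first pair differing in one place gives a 1.2-fold lower number from compound 2 to compound 4 (0.08 log units; within the scatter), with cyclopentyl in place of piperidin-1-yl on a carbonyl carbon. At this place, both the ring size and the ring nitrogen can differ without a step beyond the scatter. Nothing measured on hand explains this result. From the compounds shown here alone, it remains open whether a morpholin-4-yl group, a dimethylamino group or a longer carbon chain on this carbonyl carbon would give a step beyond the scatter. One pair also leaves open whether the same exchange would read alike with a different group on the sulfonyl.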